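Pyridin-2-yl in Place of Quinolin-8-yl on the Piperazine

The source may hold more compounds than are shown below. What is called first, only, known or untested is meant among the compounds shown, and "the series" means these compounds.

Compound 1 `O=C1c2ccccc2S(=O)(=O)N1CCCCCCN1CCN(c2ccccc2Cl)CC1`: 120 nM
Compound 2 `O=C1c2ccccc2S(=O)(=O)N1CCCCCCN1CCN(c2cccc(Cl)c2)CC1`: 233 nM
Compound 3 `O=C1c2ccccc2S(=O)(=O)N1CCCCCCN1CCN(c2cccc3cccnc23)CC1`: 21 nM

In an ADME assay on HEK293 cells for displacement of a labelled ligand from 5-hydroxytryptamine receptor 7 (Homo sapiens), read by radioligand binding, with a stated time of 1 h (a higher number here means a weaker inhibitor, a lower number a stronger inhibitor), compound 3 stands lowest of the three numbers; both steps toward it, a 5.7-fold lower number from compound 1 to compound 3 (0.76 log units; beyond the scatter) and an 11-fold lower number from compound 2 to compound 3 (1.05 log units; beyond the scatter), run downward and lie beyond the scatter, while a 1.9-fold higher number from compound 1 to compound 2 (0.29 log units; within the scatter) stays within it. Compound 4 `O=C1c2ccccc2S(=O)(=O)N1CCCCCCN1CCN(c2ccccn2)CC1` differs from compound 3 by pyridin-2-yl in place of quinolin-8-yl on an amine nitrogen in a ring. Among the measured compounds shown here, the steps that bear on this change are the two in which quinolin-8-yl entered on that ring nitrogen, a 5.7-fold lower number from compound 1 to compound 3 (0.76 log units; beyond the scatter) and an 11-fold lower number from compound 2 to compound 3 (1.05 log units; beyond the scatter); compound 4 gives up quinolin-8-yl for a smaller aromatic group, so a higher number in this assay is expected, of a size comparable to those steps but reversed. Compound 4 is therefore estimated at 150 nM, between 50 nM and 500 nM, which is expected to mean a 7.1-fold higher number from compound 3 to compound 4 (0.85 log units; beyond the scatter).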

Compound 4, inhibition constant: 552 nM
Beside the measured number, compound 4's estimate is 3.7-fold (0.57 log units) below it; the measured number lies above the stated range.
By their numbers in this assay, from the lowest: compound 3; then compounds 1 and 2 (each within the scatter of the next); then compound 4.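

In this assay the step on this amine nitrogen, a 26-fold higher number from compound 3 to compound 4 (1.42 log units; beyond the scatter) on losing the carbon-only aromatic ring of quinolin-8-yl, is the largest in the set. Pyridin-2-yl also trails both chlorophenyl groups, with a 4.6-fold higher number from compound 1 to compound 4 (0.66 log units; beyond the scatter) and with a 2.4-fold higher number from compound 2 to compound 4 (0.37 log units; beyond the scatter) as well, which leaves compound 4 the weakest of the four. Keeping a six-membered aromatic ring with its hetero atom on this nitrogen therefore did not keep the low number of compound 3. From the compounds shown here alone, how naphthalen-1-yl or pyrimidin-2-yl would read at this position stays open. No evidence given here accounts for these steps.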